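A few compounds are considered here, and "the series" means these few. Any claim that something is new, unique, unknown or untested is made for them only; others in the source may bear on it.

In an assay on microsomes from brain for inhibition of Fatty-acid amide hydrolase 1 (Rattus norvegicus), read by fluorescence and HPLC, with a stated time of 60 min (a higher number here means a weaker inhibitor, a lower number a stronger inhibitor), compound 1 `CCCCCCCCc1ccc(OCC(=O)Cn2cnnn2)cc1` gives 39 nM. Compound 2 `CCCCCCCCc1ccc(OCC(=O)Cn2ncnn2)cc1` carries 2H-tetrazol-2-yl in place of 1H-tetrazol-1-yl on a saturated chain carbon bound to a carbonyl carbon, and in this assay compound 2 gives 10 nM, so that the change made a 3.9-fold lower number from compound 1 to compound 2 (0.59 log units; beyond the scatter). Compound 3 `CC(C(=O)COc1ccc(-c2ccccc2)cc1)n1cnnn1` rests on a different core, and how it differs from the core of compound 1 is not broken down here. In this assay compound 3 reaches only a limit, > 10000 nM, one of the values sitting at the limit of > 10000 nM in this assay, at which 1 of the 3 values shown sits. Compound 4 `CC(C(=O)COc1ccc(-c2ccccc2)cc1)n1ncnn1` repeats the same kind of change on this core: 2H-tetrazol-2-yl in place of 1H-tetrazol-1-yl on a saturated chain carbon bound to a carbonyl carbon and a saturated chain carbon. The place is not identical, since the saturated chain carbon is bound to a carbonyl carbon and a saturated chain carbon rather than to a carbonyl carbon alone. Compound 3 shows only a limit, so the step is expected to be a number no higher from compound 3 to compound 4 (the limit leaves the size open), about the earlier size, yet one likely leaving compound 4 near that limit. Compound 4 is estimated at 10000 nM, between 2500 nM and 40000 nM.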

Compound 4, half-maximal inhibitory concentration: 6300 nM
The estimate for compound 4 lay 1.6-fold (0.20 log units) above the measured number; the range from low to high includes it.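

In this assay, 2H-tetrazol-2-yl in place of 1H-tetrazol-1-yl on the core of compound 3 gives an at least 1.5-fold lower number from compound 3 to compound 4 (0.20 log units; that floor lies within the scatter). Compound 3 stands only at a limit of the assay, > 10000 nM, and not at a number. The result does not go against the step on the core of compound 1, but it shows neither a matching size nor a change beyond the scatter on this second core: the same change on two cores in this assay, a 3.9-fold lower number (0.59 log units; beyond the scatter) from compound 1 to compound 2 and an at least 1.5-fold lower number (0.20 log units; that floor lies within the scatter) from compound 3 to compound 4; the limit leaves it open whether they differ

The compounds shown leave open whether an imidazole or a triazole in place of either tetrazolyl group would follow the same course. They also leave open whether 1-(2H-tetrazol-2-yl)propyl, with its longer chain, would behave as 1-(2H-tetrazol-2-yl)ethyl does.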